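Annexin A2/S100-A10 inhibition: a methoxyphenyl variant of compound 1

The compounds below may be only part of what the source reports. "The series", "measured", "known", "first", "only" and "open" are said of these compounds alone.

Measured compounds:
compound 1 `Cc1ccc(C(=O)C2=C(O)C(=O)N(CC(C)O)C2c2ccc(C(C)C)cc2)cc1`: 101%
compound 2 `Cc1ccc(C(=O)C2=C(O)C(=O)N(CC(C)O)C2c2ccc(C(C)(C)C)cc2)cc1`: 123%
compound 3 `Cc1ccc(C(=O)C2=C(O)C(=O)N(CC(C)O)C2c2cc(Cl)cc(Cl)c2)cc1`: 119%

In an assay on isolated protein for inhibition of annexin A2/S100-A10 (Homo sapiens), with a stated time of 5 min, tested at 50 uM (on this read-out higher numbers stand for more inhibition at the one concentration tested (going by the name of the read-out) and lower numbers for less inhibition), compound 1 gives the lowest of the three numbers. The step of a number 22 percentage points higher from compound 1 to compound 2 (beyond the scatter) and the step of a number 18 percentage points higher from compound 1 to compound 3 (beyond the scatter) both lie beyond the scatter, while the step of a number 4 percentage points lower from compound 2 to compound 3 (within the scatter) does not. Compound 4 `COc1cccc(C(=O)C2=C(O)C(=O)N(CC(C)O)C2c2ccc(C(C)C)cc2)c1` differs from compound 1 at another place: 3-methoxyphenyl in place of 4-methylphenyl on a carbonyl carbon. For the measured compounds named here, none of the measured steps touches the group on the carbonyl carbon, so no measured step bears directly on this change. The shared core of compound 1 gave strong inhibition in every measured case. For compound 4 a step of a number 1 percentage points lower from compound 1 to compound 4 (within the scatter) is expected, that is no change beyond the scatter. Compound 4 is therefore estimated at 100%, with a range from 70% to 125%.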

Compound 4, a percentage reported as inhibition, at one concentration (the size of the read-out at that concentration, not a potency): 110%
For compound 4 the middle estimate is 10 percentage points below the measured one; measured number inside the range.
By their numbers in this assay, from the lowest: compounds 1, 4, 3 and 2 (each within the scatter of the next, the first and the last beyond it).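

The group on the carbonyl carbon had not been varied before, and in this assay the change to 3-methoxyphenyl gives a number 9 percentage points higher from compound 1 to compound 4 (within the scatter). This position therefore takes a different substitution pattern and one added hydrogen-bond acceptor without a change beyond the scatter, and inhibition stays as high as in compound 1. Nothing available explains this result.

As far as these compounds go, it remains open whether an amine or a carboxylic acid in place of the methoxy group would give a higher, lower or level number in this assay. From the compounds shown here alone, it is also open whether 3-methoxyphenyl behaves the same way when paired with the 4-(tert-butyl)phenyl group of compound 2.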